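Working notes on cytotoxicity across the series

A few compounds are considered here, and "the series" means these few. Any claim that something is new, unique, unknown or untested is made for them only; others in the source may bear on it.

Measured compounds:
- compound 1, `O=C(COc1cccc2ccccc12)N/N=C/c1c(O)ccc2ccccc12`, 2.12 ug/mL
- compound 2, `O=C(COc1cccc2ccccc12)N/N=C/c1cccc([N+](=O)[O-])c1`, 12.1 ug/mL
- compound 3, `COc1ccc(/C=N/NC(=O)COc2cccc3ccccc23)cc1OC`, 14.7 ug/mL

All three numbers come from an ADME assay on MT4 cells (Homo sapiens) for cytotoxicity, read by MTT assay, with a stated time of 4 days; on this read-out higher numbers stand for lower toxicity in this test and lower numbers for higher toxicity in this test. Compound 2 stands second highest of the three: compound 3 sits within the scatter of it, whereas compound 1 lies well below it, beyond the scatter. Compound 4, `O=C(COc1cccc2ccccc12)N/N=C/c1cccc(Cl)c1`, has not been measured. Against compound 2 it shows (chloro in place of nitro on an aromatic carbon). Among the measured compounds shown here, no step between measured compounds covers this change, so nothing measured carries over directly. Compound 2 is the only anchor, and a step of about the size of the scatter, in either direction, is expected. The estimate for compound 4 in this assay is 10 ug/mL, between 4 ug/mL and 25 ug/mL. The expected step is a 1.2-fold lower number from compound 2 to compound 4 (0.08 log units; within the scatter).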

Compound 4, half-maximal cytotoxic concentration: 89.9 ug/mL
Beside the measured number, compound 4's estimate is 9.0-fold (0.95 log units) below it, and the stated range ends below it.
By their numbers in this assay, from the lowest: compound 1; then compounds 2 and 3 (each within the scatter of the next); then compound 4.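

In this assay, this position on the aromatic ring proves sensitive to its substituent: chloro in place of nitro gives a 7.4-fold higher number from compound 2 to compound 4 (0.87 log units; beyond the scatter). Among the compounds shown here, the earlier compounds offered no comparison differing in one place, so this is the first evidence that a single change here can move the number beyond the scatter. Nothing available explains the size of this step.

A single pair cannot separate the loss of nitro from the gain of chloro. From the compounds shown here alone, how an amine or a carboxylic acid at this position would read remains open.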